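The source may report more compounds than this note shows. Statements on the series, on what has been measured and on what is new or still open speak of the compounds shown alone.

Measured in the series:
- compound 1 `O=C(Nc1ccc(Cl)cc1)C1CCCN(C(=O)c2cccc(-c3ccco3)c2)C1`: 0%
- compound 2 `COc1cccc(C(=O)N2CCCC(C(=O)Nc3ccc(Cl)cc3)C2)c1`: 0%
- compound 3 `O=C(c1ccccc1)c1cccc(C(=O)N2CCCC(C(=O)Nc3ccc(Cl)cc3)C2)c1`: 0%

All three readings come from an ADME assay on PC-3 cells (Homo sapiens) for cytotoxicity, read by WST assay, tested at 100 uM (on this read-out higher numbers stand for more inhibition at the one concentration tested (going by the name of the read-out) and lower numbers for less inhibition), and none of the three compounds shows any inhibition at the single concentration tested. Compound 3 stands level with compounds 1 and 2 at the digits printed; the variation at this aromatic carbon has so far produced nothing that rises out of the scatter. The step of no change at the digits printed from compound 1 to compound 2 (within the scatter), the step of no change at the digits printed from compound 1 to compound 3 (within the scatter) and the step of no change at the digits printed from compound 2 to compound 3 (within the scatter) are each flat, although they exchange furan-2-yl, methoxy and benzoyl, groups that differ considerably in size and shape.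

The next compound, compound 4 `COCc1cccc(C(=O)N2CCCC(C(=O)Nc3ccc(Cl)cc3)C2)c1`, is not yet measured. It differs from compound 3 as follows: methoxymethyl in place of benzoyl on an aromatic carbon. Methoxymethyl is smaller than benzoyl and lacks the second aromatic ring, but the three flat steps above bear directly on this change, since exchanges at the same aromatic carbon covering a broad range of groups left this assay unchanged within the scatter. No step beyond the scatter is therefore expected, and the step of no change at the digits printed from compound 3 to compound 4 (within the scatter) is estimated as flat. Compound 4 is expected to give 0%, in the range -8% to 10%.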

Compound 4, a percentage reported as inhibition, at one concentration (the size of the read-out at that concentration, not a potency): 0%
Compound 4: the middle estimate sits on the measured number at the digits printed; measured number inside the range.
By their numbers in this assay, from the lowest: compounds 1, 2, 3 and 4 (each within the scatter of the next).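

In this assay, the exchange of benzoyl for methoxymethyl at this aromatic carbon gives up the second six-membered aromatic ring and the double bond outside the rings, and the result is no change at the digits printed from compound 3 to compound 4 (within the scatter). The same group set against the two other substituents gives no change at the digits printed from compound 2 to compound 4 (within the scatter) and also no change at the digits printed from compound 1 to compound 4 (within the scatter), so among the four compounds shown, the flat reading now also covers a non-ring chain carrying one oxygen, alongside methoxy, furan-2-yl and benzoyl. No measurement at hand offers an account of these flat steps.

Since all four readings sit level at a single concentration, the compounds shown leave open whether an amine, a carboxylic acid or a longer chain on this aromatic carbon would lift the reading out of the scatter. They also leave open whether a change elsewhere on the shared core, such as an amine in place of the chlorine on the anilide ring, would move the reading where this position has not.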